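The source may hold more compounds than are shown below. What is called first, only, known or untested is meant among the compounds shown, and "the series" means these compounds.

Compound 1 `COc1nc2ccc(Br)cc2cc1C(c1ccccc1)n1cc(C2CC2)nn1`: 8.22%
Compound 2 `CCCCc1cn(C(c2ccccc2)c2cc3cc(Br)ccc3nc2OC)nn1`: -3.47%
Compound 3 `COc1nc2ccc(Br)cc2cc1C(c1ccccc1)n1cc(-c2ccc(Br)cc2)nn1`: 6.28%

In an ADME assay on HEK293 cells (Homo sapiens) for cytotoxicity, read by sulforhodamine B assay, with a stated time of 48 h, tested at 10 uM (on this read-out higher numbers stand for more inhibition at the one concentration tested (going by the name of the read-out) and lower numbers for less inhibition), compound 3 lies between the other two, since a number 1.9 percentage points lower from compound 1 to compound 3 (within the scatter) and a number 9.8 percentage points higher from compound 2 to compound 3 (within the scatter) both fall within the scatter. Compound 4 `COc1nc2ccc(Br)cc2cc1C(c1ccccc1)n1cc(CCCCCO)nn1` is not yet measured; it differs from compound 3 by 5-hydroxypentyl in place of 4-bromophenyl on an aromatic carbon. All three measured steps change the group on that same aromatic carbon: a number 11.7 percentage points lower from compound 1 to compound 2 (beyond the scatter) was the only one beyond the scatter, while a number 1.9 percentage points lower from compound 1 to compound 3 (within the scatter) and a number 9.8 percentage points higher from compound 2 to compound 3 (within the scatter) were not. Going by the values given here, no measured step introduces a hydroxyl-bearing chain, so the expectation rests on the small spread seen so far. Compound 4 is therefore expected to show a number 2.3 percentage points lower from compound 3 to compound 4 (within the scatter), no step beyond the scatter. Compound 4 is estimated at 4%, between -8% and 16%.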

Compound 4, a percentage reported as inhibition, at one concentration (the size of the read-out at that concentration, not a potency): 7.96%
For compound 4 the middle estimate is 4 percentage points below the measured one, and the stated range covers the measured number.
By their numbers in this assay, from the lowest: compounds 2, 3, 4 and 1 (each within the scatter of the next, the first and the last beyond it).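

In this assay, a chain bearing a hydroxyl, 5-hydroxypentyl, sits on this aromatic carbon without a step beyond the scatter against 4-bromophenyl or cyclopropyl, with a number 1.7 percentage points higher from compound 3 to compound 4 (within the scatter) and a number 0.3 percentage points lower from compound 1 to compound 4 (within the scatter). Hydroxymethyl in place of hydrogen on the saturated chain carbon, four bonds along the chain from the aromatic carbon, gives a number 11.4 percentage points higher from compound 2 to compound 4 (beyond the scatter), so compound 2 now stands apart from both compound 1 and compound 4, though not from compound 3. No evidence is available to explain this difference. From the compounds shown here alone, whether an amine or a carboxylic acid at the end of the chain, or a longer chain, would give a number beyond the scatter remains open.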